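Benzoyl in place of oxazolylcarbonyl on a shared amide core

The source may report more compounds than this note shows. Statements on the series, on what has been measured and on what is new or still open speak of the compounds shown alone.

Measured compounds:
compound 1 `O=C(Nc1ccc(Cl)c(-c2nnc3c(Cl)cccn23)c1)c1cccc(Cl)c1` — 52700 nM
compound 2 `O=C(Nc1ccc(Cl)c(-c2nnc3c(Cl)cccn23)c1)c1ccc(Cl)cc1Cl` — 61300 nM
compound 3 `O=C(Nc1ccc(Cl)c(-c2nnc3c(Cl)cccn23)c1)c1ccon1` — 42700 nM

All numbers come from a functional assay on A549 cells (Homo sapiens) for antiproliferative activity, read by MTT assay, with a stated time of 72 h; a lower number here means a stronger inhibitor, a higher number a weaker inhibitor. Compound 3 gives the lowest number of the measured set, but its steps to the others are small: a 1.2-fold lower number from compound 1 to compound 3 (0.09 log units; within the scatter) and a 1.4-fold lower number from compound 2 to compound 3 (0.16 log units; within the scatter). Between the two chlorophenyl analogues the step is likewise small, a 1.2-fold higher number from compound 1 to compound 2 (0.07 log units; within the scatter). Nothing in these steps rises above the scatter, so compound 3 cannot be called stronger than compounds 1 or 2 on this evidence.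

Compound 4 `O=C(Nc1ccc(Cl)c(-c2nnc3c(Cl)cccn23)c1)c1ccccc1` is not yet measured. It differs from compound 3 by phenyl in place of 1,2-oxazol-3-yl on a carbonyl carbon. The closest precedents are the exchanges of the group on the carbonyl carbon already seen: a 3-chlorophenyl, a 2,4-dichlorophenyl and a 1,2-oxazol-3-yl all gave numbers within the scatter of one another. An unsubstituted phenyl on the same carbonyl carbon is therefore expected to behave alike, with a step of a 1.2-fold higher number from compound 3 to compound 4 (0.07 log units; within the scatter) in this assay, that is, none beyond the scatter. Compound 4 is estimated at 50000 nM in this assay, with a range from 25000 nM to 100000 nM.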

Compound 4, half-maximal inhibitory concentration: 76900 nM
Beside the measured number, compound 4's estimate is 1.5-fold (0.19 log units) below it; measured number inside the range.
By their numbers in this assay, from the lowest: compounds 3, 1, 2 and 4 (each within the scatter of the next).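

In this assay, the unsubstituted phenyl adds a bare ring to the groups tried on the carbonyl carbon, and exchanging the 1,2-oxazol-3-yl for it gives a 1.8-fold higher number from compound 3 to compound 4 (0.26 log units; within the scatter), so this change of ring does not separate the two compounds. Within the data shown here, the new compound also tests the chloro substituents on that phenyl directly: hydrogen in place of chloro on an aromatic carbon gives a 1.5-fold higher number from compound 1 to compound 4 (0.16 log units; within the scatter), and phenyl in place of 2,4-dichlorophenyl gives a 1.3-fold higher number from compound 2 to compound 4 (0.10 log units; within the scatter), so neither the single chloro nor the pair can be told apart from the bare ring in this assay. All six pairs among the four compounds now lie within the scatter, and this position has not yet produced a difference that can be read, whether the ring is a substituted phenyl, a plain phenyl or a 1,2-oxazol-3-yl.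

Nothing shown here offers an explanation for these numbers. From the compounds shown here alone, it remains open whether an amine or a carboxylic acid on the phenyl ring, or a longer alkyl chain in place of the ring on the carbonyl carbon, would give a step beyond the scatter.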